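This account rests on a few compounds, and the source may have more. Where it says the series, first, only, none or still open, it means among the compounds named here.

In a functional assay on HL-60 cells (Homo sapiens) for antiproliferative activity, with a stated time of 72 h (a higher number here means a weaker inhibitor, a lower number a stronger inhibitor), the three measured compounds are:

compound 1, `CCCC#Cc1cc([C@@H]2O[C@H](CO)[C@@H](O)[C@H]2O)n2ncnc(N)c12`, with 200 nM
compound 2, `CCCCC#Cc1cc([C@@H]2O[C@H](CO)[C@@H](O)[C@H]2O)n2ncnc(N)c12`, with 400 nM
compound 3, `Nc1ncnn2c([C@@H]3O[C@H](CO)[C@@H](O)[C@H]3O)cc(C#Cc3cccs3)c12`, with > 100000 nM

The value of compound 3 is a limit of the assay, not a number, and the same holds for (the limit of > 100000 nM in this assay, at which 1 of the 3 values shown sits). Among the two numbers, compound 1 gives the lower one, and its nearest neighbour is compound 2, separated by a 2.0-fold higher number from compound 1 to compound 2 (0.30 log units; within the scatter), which adds methyl in place of hydrogen on a saturated chain carbon, three bonds along the chain from a triple-bonded carbon. The step to the limit is a different matter: an at least 500-fold higher number from compound 1 to compound 3 (2.69 log units; beyond the scatter), with thiophen-2-yl in place of propyl on a triple-bonded carbon, and an at least 250-fold higher number from compound 2 to compound 3 (2.39 log units; beyond the scatter), with thiophen-2-yl in place of butyl on a triple-bonded carbon.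

Compound 4, `Nc1ncnn2c([C@@H]3O[C@H](CO)[C@@H](O)[C@H]3O)cc(-c3ccccc3F)c12`, has not been measured. It differs from compound 1 by 2-fluorophenyl in place of pent-1-yn-1-yl on an aromatic carbon. Within the data shown here, no measured step removes the triple bond, so the evidence is indirect; the closest is the large loss from compound 1 to compound 3 when an aromatic ring enters at the triple-bonded carbon. On that basis compound 4 is expected to show a large step towards a higher number, a 100-fold higher number from compound 1 to compound 4 (2.00 log units; beyond the scatter), and its value in this assay is estimated at 20000 nM, within 1500 nM to 150000 nM.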

Compound 4, half-maximal inhibitory concentration: > 100000 nM
Compound 4 gave a limit, no number (the forecaster's own chance of this, stated with the estimate: 35%); at least 5.0-fold (0.69 log units) between middle value and limit.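

In this assay, among these compounds, the earlier compounds varied only the group on the triple-bonded carbon, whereas compound 4 has no triple bond and carries 2-fluorophenyl on the aromatic carbon itself, which gives an at least 500-fold higher number from compound 1 to compound 4 (2.69 log units; beyond the scatter) and an at least 250-fold higher number from compound 2 to compound 4 (2.39 log units; beyond the scatter). Activity at this position is therefore lost with an aromatic ring both with the triple bond in place and without it, and the two compounds that carry such a ring, compound 3 and compound 4, now share one limit: the limit of > 100000 nM in this assay, at which 2 of the 4 values shown sit. As both are limits rather than numbers, the step between them cannot be read, and 2-fluorophenyl cannot be ranked against 2-(thiophen-2-yl)ethynyl.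

The compounds shown leave open whether the triple bond itself matters, since only a saturated chain such as pentyl on the same aromatic carbon would separate the triple bond from the chain it carries. They also leave open whether the loss in compound 4 belongs to the aromatic ring as such or to its fluorine, which an unsubstituted phenyl would test, and whether an amine or a hydroxyl at the end of the pent-1-yn-1-yl chain is tolerated.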